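A 4-azidophenyl group on the shared core

A few compounds are considered here, and "the series" means these few. Any claim that something is new, unique, unknown or untested is made for them only; others in the source may bear on it.

Of the compounds shown here, three on one shared core have numbers so far in a functional assay on MCF7 cells (Homo sapiens) for antiproliferative activity, read by MTT assay, with stated times of 24 h and 72 h (on this read-out higher numbers stand for weaker inhibition and lower numbers for stronger inhibition), on the read-out of half-maximal inhibitory concentration. Compound 1 (`COc1ccc([C@@H]2[C@H](Oc3ccccc3)C(=O)N2c2cc(OC)c(OC)c(OC)c2)cc1`) gives 35000 nM and compound 2 (`COc1cc(N2C(=O)[C@@H](Oc3ccccc3)[C@H]2c2ccc(C#N)cc2)cc(OC)c1OC`) gives 31600 nM while compound 3 (`COc1ccc([C@@H]2[C@H](Oc3ccccc3)C(=O)N2c2cc(OC)c(OC)c(OC)c2)cc1[N+](=O)[O-]`) stands at 69000 nM on the same scale. The steps that arrive at that last number are small: a 2.0-fold higher number from compound 1 to compound 3 (0.29 log units; within the scatter) and, modestly, a 2.2-fold higher number from compound 2 to compound 3 (0.34 log units; beyond the scatter) as well.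

Compound 4 (`COc1cc(N2C(=O)[C@@H](Oc3ccccc3)[C@H]2c2ccc(N=[N+]=[N-])cc2)cc(OC)c1OC`) has no number yet. It carries 4-azidophenyl in place of 4-methoxy-3-nitrophenyl on a saturated ring carbon. The other measured change on this aryl group, cyano in place of methoxy, gave a 1.1-fold lower number from compound 1 to compound 2 (0.04 log units; within the scatter) and so moved the number very little. Within the data shown here, no measured compound carries an azide, so the data offer no direct precedent. The nearest guide is compound 2, which with its 4-cyanophenyl group gives 31600 nM and also lacks the nitro group. In this assay the expected change is a 2.0-fold lower number from compound 3 to compound 4 (0.29 log units; within the scatter) as an estimate, a step no larger than those already measured. Compound 4 is estimated at 35000 nM with an expected range from 15000 nM to 75000 nM in most repeat measurements.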

Compound 4, half-maximal inhibitory concentration: 23000 nM
For compound 4 the middle estimate is 1.5-fold (0.18 log units) above the measured one; the range from low to high includes it.
By their numbers in this assay, from the lowest: compounds 4, 2, 1 and 3 (each within the scatter of the next, the first and the last beyond it).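

In this assay, the 4-azidophenyl group joins 4-cyanophenyl in standing apart from the 4-methoxy-3-nitrophenyl group of compound 3, with a 3.0-fold lower number from compound 3 to compound 4 (0.48 log units; beyond the scatter), a modest step but one beyond the scatter. Azido, a kind of group new to this series, cannot be told apart from the two groups it is compared with on the aromatic carbon: it gives a 1.4-fold lower number from compound 2 to compound 4 (0.14 log units; within the scatter) in place of cyano and a 1.5-fold lower number from compound 1 to compound 4 (0.18 log units; within the scatter) in place of methoxy, so three quite different groups on this aryl ring fall within the scatter of one another, while only the nitro-bearing compound 3 stands apart, and even that does not hold against compound 1, whose step to compound 3 lies within the scatter. Nothing available here accounts for these differences or for the lack of them.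

On these data alone, whether an amine or a carboxylic acid on this aryl group would stay in the same narrow range remains open. Also open, as far as these compounds go, is whether a change to the phenoxy group would move the number further than any change on the aryl group has so far.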